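A few compounds are considered here, and "the series" means these few. Any claim that something is new, unique, unknown or untested is made for them only; others in the source may bear on it.

Measured so far in a functional assay on MCF7 cells (Homo sapiens) for antiproliferative activity, read by MTT assay, with a stated time of 72 h; on this read-out higher numbers stand for weaker inhibition and lower numbers for stronger inhibition
- compound 1 `COc1ccc(/C=C2\S/C(=N\c3ccc(Cl)cc3)N(C)C2=O)cc1` gives 39300 nM
- compound 2 `COc1ccc(/C=C2/CN(C)/C(=N/c3ccc(C(F)(F)F)cc3)S2)cc1` gives 24100 nM
- compound 3 `FC(F)(F)c1cc(/N=C2/NC/C(=C/c3ccccc3)S2)cc(C(F)(F)F)c1` gives 13500 nM

Compound 1 at 39300 nM has the highest of these three numbers, within the scatter of compound 2 and beyond the scatter of compound 3.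

Compound 4 `COc1ccc(/C=C2\S/C(=N\c3ccc(OC)cc3)N(C)C2=O)cc1` differs from compound 1 in one place by methoxy in place of chloro on an aromatic carbon and this is methoxy in place of chloro on an aromatic carbon, para to a large group. Among the measured compounds shown here, no measured pair shows this change, so no shift beyond the scatter is expected in this assay on present data. The estimated 1.2-fold lower number from compound 1 to compound 4 (0.08 log units; within the scatter) lies within the scatter. Compound 4 is expected at 33000 nM with an estimated range of 14000 nM to 75000 nM.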

Compound 4, half-maximal inhibitory concentration: > 100000 nM
Compound 4: no number, only a limit (the forecaster's own chance of this, stated with the estimate: 15%); at least 3.0-fold (0.48 log units) between middle value and limit.
By their numbers in this assay, from the lowest: compounds 3, 2 and 1 (each within the scatter of the next, the first and the last beyond it). At a limit, above all of these: compound 4.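

Compound 4 gives > 100000 nM in this assay, which is a limit of the assay and not a number. This gives the series its first one-place comparison: 4-chlorophenyl to 4-methoxyphenyl yields an at least 2.5-fold higher number from compound 1 to compound 4 (0.40 log units; beyond the scatter), so a change at this place, para to a large group, can move the read-out beyond the scatter. The full size of the step stays unknown: the limit of > 100000 nM in this assay, at which 1 of the 4 values shown sits.

The compounds shown leave open how a hydroxyl, an amine or an ethoxy group would read at this place. They also leave open whether methoxy in place of chloro gives a similar step on the core of compound 2.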